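Indolyl in place of fluorophenyl on the enone series

The source may hold more compounds than are shown below. What is called first, only, known or untested is meant among the compounds shown, and "the series" means these compounds.

Three compounds sharing the enone core carry values in a functional assay on DU-145 cells (Homo sapiens) for inhibition, read by trypan blue exclusion, with a stated time of 96 h; a lower number here means a stronger inhibitor of growth, a higher number a weaker inhibitor of growth. Compound 1 `O=C(/C(=C\c1ccccc1OCc1ccccc1)Sc1ccc(F)cc1)c1ccc(Cl)cc1` gives 1000 nM. Compound 2 `O=C(/C(=C\c1ccc(Cl)cc1)SCc1ccccc1Cl)c1ccc(Cl)cc1` gives 12000 nM in this assay. Compound 3 `Cc1ccc(CS/C(=C/c2ccccc2F)C(=O)c2ccc(Cl)cc2)cc1` gives 10000 nM in this assay, the second highest of the three numbers; its nearest neighbour is compound 2, within the usual scatter, and the furthest is compound 1, whose lower number lies beyond the scatter. Going by the values given here, no pair of measured compounds differs in only one place, so no single-point change has a measured size here.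

Compound 4 `Cc1ccc(CS/C(=C/c2c[nH]c3ccc(Cl)cc23)C(=O)c2ccc(Cl)cc2)cc1` has not been measured. It differs from compound 3 in one place: 5-chloro-1H-indol-3-yl in place of 2-fluorophenyl on a double-bonded chain carbon bound to a double-bonded chain carbon. The entering group carries a hydrogen-bond donor where the leaving group carried none. Nothing in the measured set isolates the effect of this position, so any expectation in this assay rests on the spread of the three numbers alone. Compound 3 starts from 10000 nM, in the upper part of that spread, which leaves room for a lower number. The expected step is a 2.0-fold lower number from compound 3 to compound 4 (0.30 log units; within the scatter), toward a lower number and of modest size. For compound 4 the expected value in this assay is 5000 nM, within 1000 nM to 20000 nM.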

Compound 4, concentration for 50% growth inhibition: 1000 nM
Compound 4: middle estimate off by 5.0-fold (0.70 log units), on the high side; measured number inside the range.
By their numbers in this assay, from the lowest: compounds 1 and 4 (each within the scatter of the next); then compounds 3 and 2 (each within the scatter of the next).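

In this assay, 5-chloro-1H-indol-3-yl in place of 2-fluorophenyl gives a 10-fold lower number from compound 3 to compound 4 (1.00 log units; beyond the scatter), the first measured size of a single-place change in this series. Going by these compounds alone, the step shows that the group on a double-bonded chain carbon bound to a double-bonded chain carbon can shift the growth-inhibition read-out by more than the usual scatter, which the earlier compounds could not show because no two of them differed in one place. Nothing measured here bears on what underlies the step.

Going by these compounds, the change brings in the fused ring, the chlorine and the hydrogen-bond donor together, so the share of each remains open; plain 1H-indol-3-yl without the chlorine would begin to separate them. On these data alone, whether the step holds with the other groups carried by compound 1 and compound 2 also remains open.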